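Replacing the diisopropylamine with a phenylethylamine

This account rests on a few compounds, and the source may have more. Where it says the series, first, only, none or still open, it means among the compounds named here.

Of the compounds shown here, three sharing one core have been measured in a functional assay on SK-BR-3 cells (Homo sapiens) for antiproliferative activity; on this read-out lower numbers stand for stronger inhibition and higher numbers for weaker inhibition. Compound 1 `CC(=O)Oc1ccc(C(=O)Nc2cc3ccc(OCC4CCCNC4)c(C)c3oc2=O)cc1CC=C(C)C` gives 620 nM, compound 2 `CC(C)=CCc1cc(C(=O)Nc2cc3ccc(OCCCN(C)C(C)C)c(C)c3oc2=O)ccc1O` gives 570 nM, and compound 3 `CC(C)=CCc1cc(C(=O)Nc2cc3ccc(OCCCN(C(C)C)C(C)C)c(C)c3oc2=O)ccc1O` gives 1600 nM. Compound 3 therefore stands at the highest number of the three, meaning the weakest inhibition; its gaps to compound 1 and to compound 2 both lie beyond the usual scatter of repeated measurements.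

Going by the values given here, the one step with a single point of difference among the measured compounds is a 2.8-fold higher number from compound 2 to compound 3 (0.45 log units; beyond the scatter); enlarging the substituent on the amine nitrogen was accompanied by a modest loss of inhibition.

Compound 4 `CC(C)=CCc1cc(C(=O)Nc2cc3ccc(OCCCN[C@H](C)c4ccccc4)c(C)c3oc2=O)ccc1O` has not yet been measured. It differs from compound 3 in one place: (1-phenylethyl)amino in place of diisopropylamino on a saturated chain carbon, three bonds along the chain from an oxygen on an aromatic ring. Compound 1 and compound 2, which carry amine groups other than diisopropylamino, both give lower numbers than compound 3, and compound 1, whose amine also carries a hydrogen-bond donor, gives 620 nM. Among the compounds with values here, with only one directly comparable step, the direction is uncertain, but a return toward the numbers of compound 1 and compound 2 seems the most plausible expectation. Compound 4 is therefore expected to give about 800 nM in this assay, within a range of 300 nM to 2500 nM, which corresponds to an estimated step of a 2.0-fold lower number from compound 3 to compound 4 (0.30 log units; within the scatter).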

Compound 4, half-maximal inhibitory concentration: 1000 nM
Beside the measured number, compound 4's estimate is 1.3-fold (0.10 log units) below it, and the stated range covers the measured number.
By their numbers in this assay, from the lowest: compounds 2, 1, 4 and 3 (each within the scatter of the next, the first and the last beyond it).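

At the end of this chain, on a saturated chain carbon three bonds along from an oxygen on an aromatic ring, the new group differs from diisopropylamino in bringing a six-membered aromatic ring of carbon only, a hydrogen-bond donor and a defined stereocentre, yet this assay shows only a 1.6-fold lower number from compound 3 to compound 4 (0.20 log units; within the scatter). The second comparison, with the isopropyl(methyl)amino group, shows a 1.8-fold higher number from compound 2 to compound 4 (0.24 log units; within the scatter), so compound 4 cannot be told apart from either neighbour, even though those two neighbours do differ from each other beyond the scatter; at this position, then, a bulkier amine group carrying a ring keeps a number in the same range as these smaller open-chain amines. Nothing measured on these compounds offers an explanation for this result.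

Compound 4 brings in the ring, the donor and the stereocentre all at once, so the compounds shown cannot say what each contributes on its own. A plain benzylamino group, the mirror-image form of (1-phenylethyl)amino, or its tertiary N-methyl version would begin to separate these three features.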